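A few compounds are considered here, and "the series" means these few. Any claim that something is new, unique, unknown or untested is made for them only; others in the source may bear on it.

Measured so far in an in vitro ADME assay on microsomes from liver (Homo sapiens) for metabolic stability; on this read-out lower numbers stand for slow clearance and higher numbers for fast clearance:
- Compound 1 `Nc1cc(Nc2ccc(Oc3ccc(Cl)cc3)cc2)ncn1`: < 14 mL.min-1.g-1 (a limit)
- Compound 2 `Nc1cnnc(Nc2ccc(Oc3ccc(Cl)cc3)cc2)c1`: < 14 mL.min-1.g-1 (a limit)
- Compound 3 `Nc1nsc(Nc2ccc(Oc3ccc(Cl)cc3)cc2)n1`: < 14 mL.min-1.g-1 (a limit)

Compound 3 stands at < 14 mL.min-1.g-1, which is a limit and not a number. All three compounds share it: the limit of < 14 mL.min-1.g-1 in this assay, at which 3 of the 3 values shown sit.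

Compound 4 `Nc1nnc(Nc2ccc(Oc3ccc(Cl)cc3)cc2)s1` keeps the shared core but carries 5-amino-1,3,4-thiadiazol-2-yl in place of 3-amino-1,2,4-thiadiazol-5-yl on a nitrogen on an aromatic ring.

The nearest measured swaps of this group give no size: a step that the two limits leave unreadable from compound 1 to compound 2, a step that the two limits leave unreadable from compound 1 to compound 3 and a step that the two limits leave unreadable from compound 2 to compound 3.

With no measured size to go on, the expected step in this assay is none beyond the scatter: a step that the limit leaves unreadable from compound 3 to compound 4.

For compound 4 the estimate is 10 mL.min-1.g-1, with an expected range from 5 mL.min-1.g-1 to 22 mL.min-1.g-1.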

Compound 4, intrinsic clearance in microsomes: < 14 mL.min-1.g-1
Compound 4 gave a limit, no number; the forecaster's own chance of this, stated with the estimate: 75%; the middle value does not contradict the limit.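

No step can be read between compound 4 and compound 1, compound 2 or compound 3, because each gives a limit and not a number: the limit of < 14 mL.min-1.g-1 in this assay, at which 4 of the 4 values shown sit. On these data alone, whether these four amino-bearing groups differ at all in this assay stays open.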